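Phosphorylation of a Thymidine Analogue Compared Across Two Cores

The source may hold more compounds than are shown below. What is called first, only, known or untested is meant among the compounds shown, and "the series" means these compounds.

Three nucleoside-like compounds were examined in an assay on isolated protein for inhibition of thymidine kinase, cytosolic (Homo sapiens); a higher number here means a weaker inhibitor, a lower number a stronger inhibitor. Compound 2 `Cc1cn([C@@H]2O[C@H](CO)[C@@H](CN)[C@H]2O)c(=O)[nH]c1=O` gives 110000 nM in this assay. Compound 1 `Cc1cn([C@@H]2O[C@H](COP(=O)(O)O)[C@@H](CN)[C@H]2O)c(=O)[nH]c1=O`, which carries a group of 4 heavy atoms (3 oxygen, 1 phosphorus; no ring) in place of a hydrogen atom, on an oxygen on a saturated carbon, gives 280000 nM in this assay, so the change made a 2.5-fold higher number from compound 2 to compound 1 (0.41 log units; beyond the scatter). Compound 3 `Cc1cn([C@H]2C[C@H](CO)[C@@H](CO)O2)c(=O)[nH]c1=O` rests on a different core; the difference between the two cores is not broken down here. In this assay compound 3 gives 420000 nM.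

Compound 4 `Cc1cn([C@H]2C[C@H](CO)[C@@H](COP(=O)(O)O)O2)c(=O)[nH]c1=O` is not yet measured. It differs from compound 3 by a group of 4 heavy atoms (3 oxygen, 1 phosphorus; no ring) in place of a hydrogen atom, on an oxygen on a saturated carbon, which is the same change as that from compound 2 to compound 1, placed in the same surroundings. Because the earlier step gave a 2.5-fold higher number from compound 2 to compound 1 (0.41 log units; beyond the scatter), the step in this assay is expected to be a 2.4-fold higher number from compound 3 to compound 4 (0.38 log units; beyond the scatter). Compound 4 is therefore estimated to give 1000000 nM in this assay, between 400000 nM and 2500000 nM.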

Compound 4, inhibition constant: 43500 nM
Estimate against measurement, compound 4: 23-fold (1.36 log units) above; the whole stated range lies above it.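

In this assay, the same phosphorus-bearing group on an oxygen on a saturated carbon gave a 9.7-fold lower number from compound 3 to compound 4 (0.98 log units; beyond the scatter), so the change did not carry over from one core to the other in either direction or size: the same change on two cores in this assay, a 2.5-fold higher number (0.41 log units; beyond the scatter) from compound 2 to compound 1 and a 9.7-fold lower number (0.98 log units; beyond the scatter) from compound 3 to compound 4, 25-fold (1.39 log units) apart, beyond the scatter of two such steps. This shows that, in these two pairs, the outcome of the change depends on the core that carries it. It does not show which difference between the cores matters, and with one pair per core it gives no rule for any other core.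

The compounds shown leave open which feature of the cores separates the two steps. They also leave open how a carboxylic acid in place of the phosphorus-bearing group would behave on each core.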